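Swapping Cyclohexyl for 2-Bromophenyl on the Shared Core

This account rests on a few compounds, and the source may have more. Where it says the series, first, only, none or still open, it means among the compounds named here.

Compound 1 `S=c1oc(-c2ccc3c(c2)OCCO3)nn1CNC1CCCCC1`: 18400 nM
Compound 2 `CCCCCCCCCCCCCCCCNCn1nc(-c2ccc3c(c2)OCCO3)oc1=S`: 22900 nM
Compound 3 `FC(F)(F)c1cc(NCn2nc(-c3ccc4c(c3)OCCO4)oc2=S)cc(C(F)(F)F)c1`: 9320 nM

All three share one core and were tested in a functional assay, with a stated time of 6 min; on this read-out higher numbers stand for weaker inhibition and lower numbers for stronger inhibition. Compound 1 stands second highest of the three numbers; the gap to compound 2 and the gap to compound 3 both lie within the usual scatter, so none of the three can be called stronger or weaker than the others. Compound 4 `S=c1oc(-c2ccc3c(c2)OCCO3)nn1CNc1ccccc1Br` has not yet been measured. It differs from compound 1 by 2-bromophenyl in place of cyclohexyl on an amine nitrogen. Among the compounds with values here, no pair of measured compounds shows this change, so any expectation rests on compound 3, which also carries an aromatic ring on the amine nitrogen. For compound 4 the expected step is a 1.5-fold lower number from compound 1 to compound 4 (0.19 log units; within the scatter), a shift toward a lower number that need not exceed the scatter, because in this assay compound 3 gives 9320 nM. Compound 4 is therefore estimated at 12000 nM, expected between 4000 nM and 35000 nM.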

Compound 4, half-maximal inhibitory concentration: 12700 nM
For compound 4 the middle estimate is 1.1-fold (0.02 log units) below the measured one; measured number inside the range.
By their numbers in this assay, from the lowest: compounds 3, 4, 1 and 2 (each within the scatter of the next, the first and the last beyond it).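

Within the data shown here, putting 2-bromophenyl in place of cyclohexyl on the amine nitrogen gives a 1.4-fold lower number from compound 1 to compound 4 (0.16 log units; within the scatter) in this assay and so offers the first direct comparison at this position. On this evidence, a saturated carbon ring and a brominated aromatic ring cannot be told apart here. No available data bear on why the two compounds read alike.

As far as these compounds go, whether the aromatic ring or the bromine has any effect of its own remains open. Plain phenyl on the same amine nitrogen would help separate the two.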